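Swapping hydroxy for ethylamino on compound 2

The source may hold more compounds than are shown below. What is called first, only, known or untested is meant among the compounds shown, and "the series" means these compounds.

Among the compounds with values here, in a functional assay on HCT-8 cells (Homo sapiens) for antiproliferative activity, read by MTT assay, with a stated time of 48 h (a lower number here means a stronger inhibitor, a higher number a weaker inhibitor), compound 2 (`C=C(c1ccc(OC)cc1NC(=O)CO)c1ccc(OC)c2c1C=CC(C)(C)O2`) gives 470 nM and holds the lower of the two numbers measured so far. Compound 1 (`CCNCC(=O)Nc1cc(OC)ccc1C(=O)c1ccc2c(c1)C=CC(C)(C)O2`) has a different core and gives 3990 nM in the same test, a gap beyond the usual scatter. Compound 3 (`C=C(c1ccc(OC)cc1NC(=O)CNCC)c1ccc(OC)c2c1C=CC(C)(C)O2`) keeps the core of compound 2 and alters one group: ethylamino in place of hydroxy on a saturated chain carbon bound to a carbonyl carbon places ethylamino in place of hydroxy on a saturated chain carbon bound to a carbonyl carbon. Within the data shown here, no measured pair shows this change alone. Among the measured compounds shown here, the only guide is compound 1 with its 3990 nM and the same ethylamino group, but its core differs, so it is weak evidence. The expected result is a 1.3-fold higher number from compound 2 to compound 3 (0.11 log units; within the scatter) and so a slight rise that stays within the scatter. Compound 3 is estimated at 600 nM with an expected range of 180 nM to 2000 nM in this test.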

Compound 3, half-maximal inhibitory concentration: 3050 nM
Beside the measured number, compound 3's estimate is 5.1-fold (0.71 log units) below it; the whole stated range lies below it.
By their numbers in this assay, from the lowest: compound 2; then compounds 3 and 1 (each within the scatter of the next).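

On the shared core, this assay now gives a direct reading of this change: ethylamino in place of hydroxy on a saturated chain carbon bound to a carbonyl carbon produces a 6.5-fold higher number from compound 2 to compound 3 (0.81 log units; beyond the scatter) and so the position responds clearly to what is placed there. Both groups count one hydrogen-bond donor, one hydrogen-bond acceptor and no net charge, so those counts do not separate them, while the heavy atoms go from 1 to 3. No measurement at hand explains the step.

Still open, from the compounds shown here alone, is whether the rise follows the nitrogen or the two added carbons, which a plain amino or a methylamino group at this place could help separate. Also open, going by these compounds, is how a carboxylic acid or a longer chain would fare here.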